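Methoxy to hydroxy on a pyrazole-linked phenyl ring

The source may hold more compounds than are shown below. What is called first, only, known or untested is meant among the compounds shown, and "the series" means these compounds.

Of the compounds shown here, two sharing one core have been measured. Compound 1 `Cc1cc(O)cc(-c2nn(CC#N)cc2-c2ccnc(-c3ccc(Oc4ccccc4)cc3)c2)c1` carries a hydroxy group and a phenoxy-substituted aryl; in a functional assay on M14 cells (Homo sapiens) for inhibition, read by sulforhodamine B assay, with a stated time of 48 h (on this read-out lower numbers stand for stronger inhibition of growth and higher numbers for weaker inhibition of growth), compound 1 gives 3120 nM. Compound 2 `COc1cc(C)cc(-c2nn(CC#N)cc2-c2ccnc(-c3ccc(N(C)C)cc3)c2)c1` instead carries a methoxy group and a dimethylamino-substituted aryl; in this assay compound 2 gives 769 nM, the lower of the two numbers, and the gap to compound 1 lies beyond the usual scatter. Compound 3 `Cc1cc(O)cc(-c2nn(CC#N)cc2-c2ccnc(-c3ccc(N(C)C)cc3)c2)c1` has not yet been measured. It differs from compound 2 in one place: hydrogen in place of methyl on an oxygen on an aromatic ring, that is, methoxy to hydroxy, so that 3-methoxy-5-methylphenyl becomes 3-hydroxy-5-methylphenyl. Going by the values given here, no measured pair isolates this exact change, so the expected step in this assay is small, in no sure direction, most likely within the scatter. Compound 3 is therefore estimated at 900 nM, with a range from 300 nM to 3000 nM, an expected step of a 1.2-fold higher number from compound 2 to compound 3 (0.07 log units; within the scatter).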

Compound 3, concentration for total growth inhibition: 4760 nM
For compound 3 the middle estimate is 5.3-fold (0.72 log units) below the measured one, and the stated range ends below it.
By their numbers in this assay, from the lowest: compound 2; then compounds 1 and 3 (each within the scatter of the next).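

In this assay, the change from methoxy to hydroxy on the 3-methoxy-5-methylphenyl ring gives a 6.2-fold higher number from compound 2 to compound 3 (0.79 log units; beyond the scatter), so losing this single methyl from the oxygen is enough to weaken growth inhibition beyond the scatter. With the hydroxy group held in place, dimethylamino in place of phenoxy gives a 1.5-fold higher number from compound 1 to compound 3 (0.18 log units; within the scatter), which lies within the scatter, so this pair shows no difference that can be relied on. Nothing available gives a reason for the step from methoxy to hydroxy.

The compounds shown leave open whether a longer chain on the oxygen, such as ethoxy, or an amine in place of the methoxy group would keep the lower number of compound 2. From the compounds shown here alone, it also remains open whether the step from methoxy to hydroxy would be the same size with phenoxy in place of dimethylamino.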